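Carbamate to urea on an alkyne-linked imidazole scaffold

The compounds below may be only part of what the source reports. "The series", "measured", "known", "first", "only" and "open" are said of these compounds alone.

Compound 1 `COC(=O)N(C)CC#CCn1cncc1C`: 4.5 mg/kg
Compound 2 `CCOC(=O)N(C)CC#CCn1cncc1C`: 97 mg/kg

In a functional assay on the whole organism for agonist activity, with Mus musculus as the target (a higher number here means that more compound is needed for the effect, a lower number that less compound is needed), compound 2 gives 97 mg/kg, the highest of the two numbers, and the step of a 22-fold higher number from compound 1 to compound 2 (1.33 log units; beyond the scatter) is large. Compound 3 `Cc1cncn1CC#CCN(C)C(=O)N(C)C` differs from compound 2 by dimethylamino in place of ethoxy on a carbonyl carbon. Within the data shown here, no measured step changes this carbonyl position, so the step from compound 1 to compound 2 does not bear on it, and nothing supports an expected direction beyond the scatter. The estimate for compound 3 is therefore 80 mg/kg (range 15 mg/kg to 400 mg/kg), and the expected step is a 1.2-fold lower number from compound 2 to compound 3 (0.08 log units; within the scatter).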

Compound 3, dose for half-maximal effect: 45.2 mg/kg
The estimate for compound 3 lay 1.8-fold (0.25 log units) above the measured number; the range from low to high includes it.
By their numbers in this assay, from the lowest: compound 1; then compound 3; then compound 2.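

In this assay this carbonyl position tolerates a change of atom type, but the direction depends on the group replaced: dimethylamino in place of ethoxy gives a 2.1-fold lower number from compound 2 to compound 3 (0.33 log units; beyond the scatter) and dimethylamino in place of methoxy gives a 10-fold higher number from compound 1 to compound 3 (1.00 log units; beyond the scatter). Compound 3 therefore falls between compound 1 and compound 2, so the swap alone does not set one direction, and methoxy remains the group needing the least compound. No evidence is available to explain this order.

Going by these compounds, how methylamino or a pyrrolidine ring on this carbonyl carbon would compare remains open.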